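A few compounds are considered here, and "the series" means these few. Any claim that something is new, unique, unknown or untested is made for them only; others in the source may bear on it.

Compound 1 `Nc1nc([SeH])nc2ncccc12` was tested in a functional assay on HTB-54 cells (Homo sapiens) for cytotoxicity, read by MTT assay, with a stated time of 72 h (on this read-out higher numbers stand for weaker inhibition of growth and lower numbers for stronger inhibition of growth), and gave 96600 nM. Of the three measured compounds it shows the highest number. Compound 3 `CSc1nc(NCc2ccccc2)c2ccccc2n1` gives 82300 nM, which lies within the scatter of compound 1. Compound 2 `[SeH]c1nc([SeH])c2cccnc2n1` gives 7930 nM, and the step of a 12-fold lower number from compound 1 to compound 2 (1.09 log units; beyond the scatter) is the only one beyond the scatter among these compounds.

The next compound, compound 4 `C[Se]c1nc(N)c2cccnc2n1`, differs from compound 1 by a single change: methyl in place of hydrogen on a selenium. For the measured compounds named here, the one measured step, from compound 1 to compound 2, concerns a different kind of change, a nitrogen atom exchanged for selenium on an aromatic carbon, so it does not speak directly to capping a selenium with a methyl group. Going by the values given here, no measured step shows what that capping does.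

With nothing comparable to lean on, the expectation for compound 4 in this assay is a number close to that of compound 1, and the step of a 1.2-fold lower number from compound 1 to compound 4 (0.08 log units; within the scatter) is therefore estimated to stay within the scatter. The estimate for compound 4 is 80000 nM, within a range from 25000 nM to 250000 nM.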

Compound 4, concentration for total growth inhibition: > 100000 nM
Compound 4: only a limit was reported; the forecaster's own chance of this, stated with the estimate: 15%; middle value at least 1.2-fold (0.09 log units) away from the limit.
By their numbers in this assay, from the lowest: compound 2; then compounds 3 and 1 (each within the scatter of the next). At a limit, above all of these: compound 4.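

In this assay compound 4 gives > 100000 nM, which is a limit and not a number. Methyl in place of hydrogen on a selenium gives an at least 1.0-fold higher number from compound 1 to compound 4 (0.01 log units; that floor lies within the scatter), so capping this selenium brings no stronger inhibition of growth, something the earlier compounds could not show, as none of them carries this change. How much weaker compound 4 may truly be cannot be read, because the step rests on a limit rather than on a number: the limit of > 100000 nM in this assay, at which 1 of the 4 values shown sits.

From the compounds shown here alone, whether any other group on this selenium would behave like methyl stays open, for instance an ethyl group, a longer chain or a chain ending in a carboxylic acid. Also open, going by these compounds, is whether the same capping would act alike on compound 2, whose number lies much lower.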